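Replacing an Alkyne Arm: Expected Clearance of Compound 4

A few compounds are considered here, and "the series" means these few. Any claim that something is new, unique, unknown or untested is made for them only; others in the source may bear on it.

Three compounds have so far been tested in an ADME assay (liver) for metabolic stability, with Liver microsome (Rattus norvegicus) as the target, using microsomes and NADPH, with a stated time of 30 min, tested at 1 uM; on this read-out lower numbers stand for slow clearance and higher numbers for fast clearance:

Compound 1 `Nc1ccc(S(=O)(=O)N2CCN(c3ncc(C(O)(C(F)(F)F)C(F)(F)F)cc3C#CC3CC3)CC2)cn1` gives 67 mL.min-1.g-1.
Compound 2 `Nc1ccc(S(=O)(=O)N2CCN(c3ncc(C(O)(C(F)(F)F)C(F)(F)F)cc3-c3cnccc3F)CC2)cn1` gives 22 mL.min-1.g-1.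
Compound 3 `Nc1ccc(S(=O)(=O)N2CCN(c3ncc(C(O)(C(F)(F)F)C(F)(F)F)cc3-c3cncc(F)c3)CC2)cn1` gives 19 mL.min-1.g-1.

Compound 1 shows the highest number of the three, so it is cleared fastest among them. The two others differ from it at only one aromatic carbon of the shared core, and both steps lowered the number: a 3.0-fold lower number from compound 1 to compound 2 (0.48 log units; beyond the scatter) and a 3.5-fold lower number from compound 1 to compound 3 (0.55 log units; beyond the scatter). Compounds 2 and 3 lie within the scatter of each other, as a 1.2-fold lower number from compound 2 to compound 3 (0.06 log units; within the scatter) shows.

Compound 4 `Nc1ccc(S(=O)(=O)N2CCN(c3ncc(C(O)(C(F)(F)F)C(F)(F)F)cc3-c3ccc4scnc4c3)CC2)cn1` has not yet been measured. It differs from compound 1 in the same place: 1,3-benzothiazol-5-yl in place of 2-cyclopropylethynyl on an aromatic carbon. As in the two measured steps, an aromatic group containing hetero atoms takes the place of the 2-cyclopropylethynyl arm, so a modest lowering in this assay is expected here as well; since the entering group is built of two fused aromatic rings rather than the 4-fluoropyridin-3-yl or 5-fluoropyridin-3-yl of compounds 2 and 3, the step is expected to be somewhat smaller and less certain. The estimated step is a 1.9-fold lower number from compound 1 to compound 4 (0.28 log units; within the scatter). Compound 4 is therefore expected to give about 35 mL.min-1.g-1, within a range from 15 mL.min-1.g-1 to 80 mL.min-1.g-1.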

Compound 4, intrinsic clearance in microsomes: 147 mL.min-1.g-1
For compound 4 the middle estimate is 4.2-fold (0.62 log units) below the measured one; measured number outside the range, above it.
By their numbers in this assay, from the lowest: compounds 3 and 2 (each within the scatter of the next); then compound 1; then compound 4.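

In this assay, an aromatic group with hetero atoms at this carbon does not by itself bring slower clearance: with 1,3-benzothiazol-5-yl in place of 2-cyclopropylethynyl, the number moves the opposite way from the two fluoropyridinyl steps, giving a 2.2-fold higher number from compound 1 to compound 4 (0.34 log units; beyond the scatter). Losing the alkyne arm therefore does not settle the clearance, since the group that enters makes a large difference, as a 7.7-fold higher number from compound 3 to compound 4 (0.89 log units; beyond the scatter) and a 6.7-fold higher number from compound 2 to compound 4 (0.82 log units; beyond the scatter) show. Nothing available here explains the rise.

The compounds shown do not separate the effect of having two fused aromatic rings from that of the sulfur-containing five-membered ring. A plain phenyl or an unsubstituted pyridin-3-yl group at this carbon could help to tell these apart.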